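The compounds below may be only part of what the source reports. "The series", "measured", "known", "first", "only" and "open" are said of these compounds alone.

For the measured compounds named here, in an ADME assay on NHDF cells (Homo sapiens) for cytotoxicity, read by MTT assay, with a stated time of 72 h (a lower number here means a stronger inhibitor, a higher number a weaker inhibitor), two compounds sharing one core have numbers so far. Compound 1 `COc1ccc(/C=C2\CCC/C(=C\c3cccc(O)c3)C2=O)cc1OC` gives 6800 nM, and compound 2 `COc1ccc(/C=C2\CCC/C(=C\c3ccc(O)cc3)C2=O)cc1OC` gives 26100 nM, the higher of the two numbers and so the weaker inhibitor. Going by the values given here, the one measured step, a 3.8-fold higher number from compound 1 to compound 2 (0.58 log units; beyond the scatter), is modest but beyond the scatter, and it comes from 4-hydroxyphenyl replacing 3-hydroxyphenyl. Compound 3 `COc1ccc(/C=C2\CCC/C(=C\c3cc(Cl)cc(Cl)c3)C2=O)cc1OC` changes that same place, with 3,5-dichlorophenyl in place of 4-hydroxyphenyl on a double-bonded chain carbon bound to a double-bonded ring carbon. Among the compounds with values here, no compound with chlorine has been measured, so this single step is a weak guide. It does show that compound 1, which lacks 4-hydroxyphenyl, sits lower at 6800 nM. A step of similar modest size towards a lower number is therefore expected, a 2.9-fold lower number from compound 2 to compound 3 (0.46 log units; beyond the scatter). The estimate for compound 3 is 9000 nM, with an expected range from 3000 nM to 26000 nM.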

Compound 3, half-maximal inhibitory concentration: 8300 nM
Beside the measured number, compound 3's estimate is 1.1-fold (0.04 log units) above it; low and high end bracket the measured number.
By their numbers in this assay, from the lowest: compounds 1 and 3 (each within the scatter of the next); then compound 2.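

Replacing 4-hydroxyphenyl with 3,5-dichlorophenyl gives a 3.1-fold lower number from compound 2 to compound 3 (0.50 log units; beyond the scatter) in this assay, so a lower number at this place does not depend on keeping a hydroxy group on the ring. Replacing 3-hydroxyphenyl with the same group gives a 1.2-fold higher number from compound 1 to compound 3 (0.09 log units; within the scatter) and so separates neither group from the other, even though 3,5-dichlorophenyl has 0 hydrogen-bond donors. No measurement shown here explains why these numbers differ.

Going by these compounds, it remains open whether the chlorines matter at all, since plain phenyl at this place would be needed to show how the ring behaves with nothing attached. It is also open how an amine or a carboxylic acid on this ring would compare with the groups shown.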